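Three Measured Compounds and One Awaiting a Number

The source may report more compounds than this note shows. Statements on the series, on what has been measured and on what is new or still open speak of the compounds shown alone.

The study measures cytotoxicity in a functional assay on CCRF-CEM cells (Homo sapiens) for cytotoxicity, with a stated time of 72 h; on this read-out lower numbers stand for stronger inhibition and higher numbers for weaker inhibition. Compound 1, with the structure `C#CCOc1ccc(/C=C/C(=O)c2cccc(Br)c2)cc1OC`, gives 15200 nM in this assay. Compound 3, `C#CCOc1ccc(/C=C/C(=O)c2ccc(-n3ccnc3)cc2)cc1OC`, gives 15000 nM, and compound 1 and compound 3 sit within the scatter of each other, so neither can be called the stronger of the two. Compound 2, `C=CCOc1ccc(/C=C/C(=O)c2ccc(OCC=C(C)C)c(CC=C)c2)cc1OC`, returns only a limit of the assay, > 50000 nM, and not a number; this is the line (the limit of > 50000 nM in this assay, at which 1 of the 3 values shown sits). Among the measured compounds shown here, compound 1 thus holds one of only two numbers in the set.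

Compound 4, `C#CCOc1ccc(/C=C/C(=O)c2cccn2C)cc1OC`, has not yet been measured. It differs from compound 1 in one place: 1-methyl-1H-pyrrol-2-yl in place of 3-bromophenyl on a carbonyl carbon. For the measured compounds named here, no step between two measured compounds bears on this change, so the direction of the step is open. The estimate for compound 4 is a step of a 1.3-fold higher number from compound 1 to compound 4 (0.12 log units; within the scatter) in this assay, taken as no change beyond the scatter. Compound 4 is expected to give about 20000 nM, with a range from 6000 nM to 60000 nM.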

Compound 4, half-maximal inhibitory concentration: > 50000 nM
Compound 4 gave a limit, no number; the forecaster's own chance of this, stated with the estimate: 30%; middle value at least 2.5-fold (0.39 log units) from the limit.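

With this change the group on the carbonyl carbon gets its first readable step: in this assay, 1-methyl-1H-pyrrol-2-yl in place of 3-bromophenyl gives an at least 3.2-fold higher number from compound 1 to compound 4 (0.51 log units; beyond the scatter). The shared core and the propargyl ether chain stay the same. Compound 4 stands at a limit of the assay and not at a number, so the step gives only the smallest size the change can have, and such limits are no longer confined to a single compound: the limit of > 50000 nM in this assay, at which 2 of the 4 values shown sit.

The compounds shown leave open whether the step goes with the loss of the bromine, the smaller ring, the ring nitrogen or its methyl. They also do not show how a plain phenyl group or a 3-aminophenyl group on this carbonyl carbon would read.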